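A few compounds are considered here, and "the series" means these few. Any claim that something is new, unique, unknown or untested is made for them only; others in the source may bear on it.

Values so far in a functional assay on the whole organism (trachea) for inhibition, with Cavia porcellus as the target (on this read-out lower numbers stand for an effect already at smaller amounts and higher numbers for an effect only at larger amounts of compound), are these:
- compound 1 `O=C(O)[C@@H]1CSC(CCc2ccccc2O)N1` gives 45 mg/kg
- compound 2 `COc1ccccc1OCC1SCCN1C(=O)COC(C)=O` gives 25 mg/kg

For the measured compounds named here, compound 2 and compound 1 lie within the usual scatter of each other, so the two cannot be ranked, and no pair differing in a single place has been measured. Going by the values given here, compound 3 `COc1ccccc1OCC1SCCN1C(=O)C(C)(C)C(=O)O` keeps the rest of compound 2 but carries 1-carboxy-1-methylethyl in place of acetoxymethyl on a carbonyl carbon as its only change. Among the compounds with values here, no measured step shows what this swap does. Compound 1, a different structure that also holds a carboxy group, gives 45 mg/kg in this assay and so offers no reason to expect a large shift. The estimated size of a 1.4-fold higher number from compound 2 to compound 3 (0.15 log units; within the scatter) stays within the scatter, with no firm direction. Compound 3 is expected at 35 mg/kg with a range from 12 mg/kg to 100 mg/kg as the estimate.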

Compound 3, dose for half-maximal effect: 21 mg/kg
Compound 3: the middle estimate sits 1.7-fold (0.22 log units) above what was measured; the measured number falls inside the stated range.
By their numbers in this assay, from the lowest: compounds 3, 2 and 1 (each within the scatter of the next, the first and the last beyond it).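

In this assay, for the compounds shown here, the exchange of acetoxymethyl for 1-carboxy-1-methylethyl on a carbonyl carbon gives a 1.2-fold lower number from compound 2 to compound 3 (0.08 log units; within the scatter) and provides the first measured step at this place. The two compounds cannot be ranked, yet the step shows that this place can hold a group with a hydrogen-bond donor, which acetoxymethyl lacks, without the number moving beyond the scatter. Nothing available explains why the swap leaves the number within the scatter.

A single step cannot show whether any group on this carbonyl carbon would give a similar number, or whether an amine, a methyl ester or a longer chain would move it beyond the scatter. It also leaves open how much the carboxy group itself contributes, apart from the two methyl groups carried with it.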